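Aryl variation on the shared core: compound 4

The source may report more compounds than this note shows. Statements on the series, on what has been measured and on what is new or still open speak of the compounds shown alone.

Among the numbers shown in a functional assay on L1210 cells (Mus musculus) for cytotoxicity, with a stated time of 48 h (a higher number here means a weaker inhibitor, a lower number a stronger inhibitor), compound 3 `Clc1ccc(Cc2nn3c(Br)c(-c4ccc(Cl)cc4Cl)nc3s2)cc1` stands lowest; in this assay compound 3 gives 31000 nM. Compound 2 `COc1ccc(-c2nc3sc(Cc4ccc(Cl)cc4)nn3c2Br)cc1` gives 63000 nM in this assay. Compound 1 `Fc1ccc(-c2nc3sc(Cc4ccc(Cl)cc4)nn3c2Br)cc1` gives only > 250000 nM in this assay. For compound 1 this is the limit of > 250000 nM in this assay, at which 1 of the 3 values shown sits, a limit and not a number.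

Compound 4 `Clc1ccc(Cc2nn3c(Br)c(-c4ccccc4)nc3s2)cc1` differs from compound 3 in one place: phenyl in place of 2,4-dichlorophenyl on an aromatic carbon. Going by the values given here, two measured steps bear on this aryl group: an at least 8.0-fold lower number from compound 1 to compound 3 (0.90 log units; beyond the scatter) and a 2.0-fold lower number from compound 2 to compound 3 (0.31 log units; beyond the scatter), with an at least 3.9-fold lower number from compound 1 to compound 2 (0.59 log units; beyond the scatter) between the other two aryl groups. Each step that placed the 2,4-dichlorophenyl gave a lower number, so taking both chlorines away is expected to move the number back up, though the size is uncertain as no unsubstituted phenyl has been measured. The step of a 2.6-fold higher number from compound 3 to compound 4 (0.41 log units; beyond the scatter) is expected to be modest and upward. Compound 4 is estimated at 80000 nM, with a range from 25000 nM to 250000 nM.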

Compound 4, half-maximal inhibitory concentration: > 250000 nM
Compound 4 was reported as a limit; the forecaster's own chance of this, stated with the estimate: 20%; middle value at least 3.1-fold (0.49 log units) from the limit.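

Taking both chlorines off this aryl group gives an at least 8.0-fold higher number from compound 3 to compound 4 (0.90 log units; beyond the scatter), and hydrogen in place of methoxy gives an at least 3.9-fold higher number from compound 2 to compound 4 (0.59 log units; beyond the scatter), so in this assay the unsubstituted phenyl sits with neither of the two aryl groups that give readable numbers. A substituent on this phenyl is not enough by itself, as compound 1 goes against any such pattern: with its 4-fluorophenyl it too stands at a limit and not at a number. The step between compound 1 and compound 4 cannot be read, as both values are limits: the limit of > 250000 nM in this assay, at which 2 of the 4 values shown sit.

How far compound 1 and compound 4 lie past that limit stays open, so the order among these two aryl groups is unknown. Also open, as far as these compounds go, is whether a single chlorine on the phenyl, or an amine there, would give a readable number.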